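The source may report more compounds than this note shows. Statements on the series, on what has been measured and on what is new or still open speak of the compounds shown alone.

Measured so far:
compound 1, `CC(C)C[C@H](N)CCN(C(=O)[C@@H]1C[C@H]1c1ccccc1)c1ccc(-c2ccccc2)cc1`, 3 nM
compound 2, `CC[C@H](C)[C@H](N)CN(C(=O)[C@@H]1C[C@H]1c1ccccc1Cl)c1ccc(-c2ccccc2)cc1`, > 25000 nM

In a functional assay for agonist activity at G protein-coupled receptor 88 (Homo sapiens), read by HTRF and cAMP accumulation (on this read-out lower numbers stand for an effect already at smaller amounts and higher numbers for an effect only at larger amounts of compound), compound 1 gives 3 nM, a small amount. For compound 2 the same assay returns no number but only a limit, > 25000 nM, the boundary of what this assay can report. Compound 2 therefore stands at the weak end of the two values shown, as the limit of > 25000 nM in this assay, at which 1 of the 2 values shown sits, records. Within the data shown here, compound 1 and compound 2 differ in several places at once, so no single step between them can be read off.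

Compound 3, `CC[C@H](C)[C@H](N)CN(C(=O)[C@@H]1C[C@H]1c1nccs1)c1ccc(-c2ccccc2)cc1`, has not yet been measured. It differs from compound 2 in one place: 1,3-thiazol-2-yl in place of 2-chlorophenyl on a saturated ring carbon. No measured step of this kind exists among the compounds shown, so the size of the change in this assay cannot be anchored on a number. The expected step of an at least 1.6-fold lower number from compound 2 to compound 3 (0.22 log units; that floor lies within the scatter) is a modest one toward smaller amounts, if any beyond the scatter. Compound 3 is thus estimated at 15000 nM, within 2000 nM to 100000 nM, with a real chance that only a limit is reported again.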

Compound 3, half-maximal effective concentration: 210 nM
The estimate for compound 3 lay 71-fold (1.85 log units) above the measured number; the whole stated range lies above it.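

On the saturated ring carbon of the three-membered ring, the group placed there can separate a compound with no readable effect from one with a clear effect. In this assay compound 2, which carries 2-chlorophenyl, gives > 25000 nM, a limit of the assay and not a number. With 1,3-thiazol-2-yl in its place the result is an at least 110-fold lower number from compound 2 to compound 3 (2.07 log units; beyond the scatter), the first change shown at a single place, and it lies well beyond the scatter; as one end of this step is a limit, the step gives only a minimum size and its true size remains unknown: the limit of > 25000 nM in this assay, at which 1 of the 3 values shown sits.

The compounds shown leave open which part of the change matters: the loss of the chlorine, the five-membered ring in place of the six-membered one, or the ring's nitrogen and sulfur atoms, and a thiophen-2-yl or pyridin-2-yl group at the same place would help to separate these. Also open, going by these compounds, is how the amine-bearing side chain of compound 1 would behave with 1,3-thiazol-2-yl, as compound 1 and compound 3 differ in several places and cannot be compared directly.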